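This account rests on a few compounds, and the source may have more. Where it says the series, first, only, none or still open, it means among the compounds named here.

Measured compounds in a functional assay on SJSA-1 cells (Homo sapiens) for inhibition, read by CCK-8 assay, with a stated time of 72 h, tested at 1 uM; a higher number here means more inhibition at the concentration tested (going by the name of the read-out), a lower number less inhibition:
compound 1 `COc1ccc(OC)c(N2C(=O)CSC2c2cccc(C(=O)NCCCCc3ccccc3)c2)c1` — 48%
compound 2 `O=C(NCCCCc1ccccc1)c1cccc(C2SCC(=O)N2c2ccccc2)c1` — 73%
compound 3 `COc1cc(F)ccc1N1C(=O)CSC1c1cccc(C(=O)NCCCCc2ccccc2)c1` — 77%

Compound 1 stands lowest of the three in this assay; compound 2 is the nearest to it and compound 3 the furthest, and both of those steps lie beyond the scatter. Compound 4 `CC(F)(F)c1cccc(N2C(=O)CSC2c2cccc(C(=O)NCCCCc3ccccc3)c2)c1` is not yet measured. Its change from compound 1: a group of 10 heavy atoms (8 carbon, 2 fluorine; one six-membered aromatic ring of carbon only) in place of a group of 10 heavy atoms (8 carbon, 2 oxygen; one six-membered aromatic ring of carbon only), on an amide-type nitrogen in a ring. Both measured steps away from compound 1 replace the same 2,5-dimethoxyphenyl on the amide-type nitrogen in the ring, so both bear on this step: a number 25 percentage points higher from compound 1 to compound 2 (beyond the scatter) and a number 29 percentage points higher from compound 1 to compound 3 (beyond the scatter), while a number 4 percentage points higher from compound 2 to compound 3 (within the scatter) shows that the two replacing groups differ little from each other in this assay. A rise of comparable size is therefore expected for compound 4 in this assay, the expected step being a number 22 percentage points higher from compound 1 to compound 4 (beyond the scatter). The estimate for compound 4 is 70%, with a range of 50% to 88%.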

Compound 4, a percentage reported as inhibition, at one concentration (the size of the read-out at that concentration, not a potency): 68%
Beside the measured number, compound 4's estimate is 2 percentage points above it, and the stated range covers the measured number.
By their numbers in this assay, from the lowest: compound 1; then compounds 4, 2 and 3 (each within the scatter of the next).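

In this assay a third replacement of the 2,5-dimethoxyphenyl on the amide-type nitrogen, this one with no oxygen and no hydrogen-bond acceptors, also gives a higher number (a number 20 percentage points higher from compound 1 to compound 4 (beyond the scatter)). A 1,1-difluoroethyl on the phenyl ring brings no change that can be read (a number 5 percentage points lower from compound 2 to compound 4 (within the scatter)), and the 4-fluoro-2-methoxyphenyl group cannot be separated from it either (a number 9 percentage points lower from compound 3 to compound 4 (within the scatter)). Nothing available explains why this replacement behaves as it does.

As far as these compounds go, whether an amine or a carboxylic acid in place of the 1,1-difluoroethyl would hold the number stays open. Potency also stays open, since these numbers come from a single concentration.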